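A few compounds are considered here, and "the series" means these few. Any claim that something is new, unique, unknown or untested is made for them only; others in the source may bear on it.

Working notes on the series, read in an ADME assay on MIA PaCa-2 cells (Homo sapiens) for cytotoxicity, read by MTT assay, with a stated time of 72 h; on this read-out higher numbers stand for weaker inhibition and lower numbers for stronger inhibition. Compound 1 `COc1ccc(C2=C(c3cc(OC)c(OC)c(OC)c3)C(=O)CC2O[SiH2]C(C)(C)C)cc1` reports only a limit, > 100 ug/mL. Compound 2 `COc1cc(C2=C(c3ccccc3)C(O[SiH2]C(C)(C)C)CC2=O)cc(OC)c1OC` also reports only a limit, > 100 ug/mL. Among the compounds with values here, compound 3 `COCOc1cc(C2=C(c3cc(OC)c(OC)c(OC)c3)C(=O)CC2O[SiH2]C(C)(C)C)ccc1OC` gives 50 ug/mL, the only true number so far, and the rest of the series stands at the limit of > 100 ug/mL in this assay, at which 2 of the 3 values shown sit. Compound 4 `COc1ccc(C2=C(c3cc(OC)c(OC)c(OC)c3)C(=O)CC2O[SiH2]C(C)(C)C)cc1O` differs from compound 3 by hydrogen in place of methoxymethyl on an oxygen on an aromatic ring, or methoxymethoxy to hydroxy. The measured steps bearing on this place are an at least 2.0-fold lower number from compound 1 to compound 3 (0.30 log units; that floor lies within the scatter) and an at least 2.0-fold lower number from compound 2 to compound 3 (0.30 log units; that floor lies within the scatter). Both are floors only, so they suggest direction weakly and size hardly at all. On compound 3 and those steps, a further lowering is expected, with wide uncertainty: a 4.2-fold lower number from compound 3 to compound 4 (0.62 log units; beyond the scatter). The estimate for compound 4 is 12 ug/mL, with an expected range of 1 ug/mL to 70 ug/mL.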

Compound 4, half-maximal inhibitory concentration: 55 ug/mL
For compound 4 the middle estimate is 4.6-fold (0.66 log units) below the measured one; the measured number falls inside the stated range.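

In this assay, replacing methoxymethyl with hydrogen on this oxygen on an aromatic ring leaves no readable change: a 1.1-fold higher number from compound 3 to compound 4 (0.04 log units; within the scatter). The methoxymethyl is therefore not required for the number seen with compound 3. Hydroxy in place of hydrogen gives an at least 1.8-fold lower number from compound 1 to compound 4 (0.25 log units; that floor lies within the scatter), and 3-hydroxy-4-methoxyphenyl in place of phenyl gives an at least 1.8-fold lower number from compound 2 to compound 4 (0.25 log units; that floor lies within the scatter), but both steps are floors only: the limit of > 100 ug/mL in this assay, at which 2 of the 4 values shown sit.

Going by these compounds, the true size of those two steps remains open. Also open, on these data alone, is whether a longer chain on this oxygen, or an amine or carboxylic acid in place of the hydroxy, would move the number beyond the scatter.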